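Dimethoxyphenyl for Dichlorophenyl on the Shared Core

The source may hold more compounds than are shown below. What is called first, only, known or untested is meant among the compounds shown, and "the series" means these compounds.

Compound 1 `COc1ccc(-c2cs/c(=N\NC(=O)c3ccc(O)cc3)n2-c2ccc(OC)cc2OC)cc1` gives in a functional assay on PC-3 cells (Homo sapiens) for cytotoxicity, read by sulforhodamine B assay, with a stated time of 48 h (a higher number here means that more compound is tolerated, a lower number that less compound is tolerated), only a limit, < 100000 nM.
Compound 2 `O=C(N/N=c1\scc(-c2ccc(Cl)cc2)n1-c1ccc(Cl)cc1Cl)c1ccc(O)cc1` gives in this assay only a limit, < 100000 nM.

Compound 2 therefore stands at a limit and not at a number; both values shown sit at the limit of < 100000 nM in this assay, at which 2 of the 2 values shown sit. Compound 3 `COc1ccc(-n2c(-c3ccc(Cl)cc3)cs/c2=N\NC(=O)c2ccc(O)cc2)c(OC)c1` differs from compound 2 by 2,4-dimethoxyphenyl in place of 2,4-dichlorophenyl on an aromatic nitrogen. Among the compounds with values here, no step between measured compounds differing in one place is available, so the expectation rests on the limit of compound 2 alone, and no shift beyond the scatter in this assay is expected in either direction. Compound 3 is estimated at 50000 nM, between 10000 nM and 100000 nM. The expected step is a step that the limit leaves unreadable from compound 2 to compound 3, most likely again reported only as a limit.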

Compound 3, concentration lethal to 50% of the cells: < 100000 nM
Compound 3: no number, only a limit; the forecaster's own chance of this, stated with the estimate: 65%; the middle value is on the limit's open side.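

In this assay compound 3 gives < 100000 nM, a limit and not a number. No step from compound 1 or compound 2 to compound 3 can be read: the limit of < 100000 nM in this assay, at which 3 of the 3 values shown sit.

The compounds shown leave open whether 2,4-dimethoxyphenyl in place of 2,4-dichlorophenyl changes the value at all.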